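Thiophen-2-yl to 4-hydroxyphenyl: notes on the series

The source may report more compounds than this note shows. Statements on the series, on what has been measured and on what is new or still open speak of the compounds shown alone.

In a functional assay on SW-620 cells (Homo sapiens) for antiproliferative activity, read by MTT assay, with a stated time of 24 h (a higher number here means a weaker inhibitor, a lower number a stronger inhibitor), compound 3 `COc1ccc(C(=O)/C=C/c2cccs2)c2c1C=CC(C)(C)O2` gives > 10000 nM, which is a limit and not a number. Compound 2 `COc1ccc(C(=O)/C=C/c2ccccc2)c2c1C=CC(C)(C)O2` gives > 10000 nM, also a limit. Among the compounds with values here, compound 1 `COc1ccc(C(=O)/C=C/c2ccc(N(C)C)cc2)c2c1C=CC(C)(C)O2` gives 570 nM, the only true number so far.

Compound 4 `COc1ccc(C(=O)/C=C/c2ccc(O)cc2)c2c1C=CC(C)(C)O2` differs from compound 3 as follows: 4-hydroxyphenyl in place of thiophen-2-yl on a double-bonded chain carbon bound to a double-bonded chain carbon. Within the data shown here, two measured steps bear on this, both large: an at least 17-fold higher number from compound 1 to compound 2 (1.24 log units; beyond the scatter) and an at least 17-fold higher number from compound 1 to compound 3 (1.24 log units; beyond the scatter). The step that the two limits leave unreadable from compound 2 to compound 3 adds nothing. Compound 4 keeps a para-free reading of neither end: it carries a substituted phenyl like compound 1, with a different group, so only partial recovery is expected. The expected step is an at least 3.3-fold lower number from compound 3 to compound 4 (0.52 log units; beyond the scatter), towards a lower number, and a further limit remains possible. Compound 4 is estimated at 3000 nM, within 700 nM to 10000 nM.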

Compound 4, half-maximal inhibitory concentration: > 10000 nM
Compound 4: no number, only a limit; the forecaster's own chance of this, stated with the estimate: 35%; at least 3.3-fold (0.52 log units) between middle value and limit.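

In this assay the value of compound 4, > 10000 nM, is a limit and not a number. Hydroxy in place of dimethylamino on an aromatic carbon gives an at least 17-fold higher number from compound 1 to compound 4 (1.24 log units; beyond the scatter), so a substituent on the phenyl ring does not by itself restore a measurable value, and of the compounds shown only compound 1 gives a true number. The steps from compound 2 and compound 3 to compound 4 cannot be read, as the comparison ends at the assay ceiling: the limit of > 10000 nM in this assay, at which 3 of the 4 values shown sit.

On these data alone, whether methylamino or another amine on that aromatic carbon would give a true number remains open. As far as these compounds go, how far compound 2, compound 3 and compound 4 differ beyond the limit also remains open.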